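Dihalomethyl replacement on the thiazole series: one cytostatic read-out

This account rests on a few compounds, and the source may have more. Where it says the series, first, only, none or still open, it means among the compounds named here.

Measured so far:
- compound 1, `CC(C)OC(=O)c1sc(-c2ccc(Cl)cc2)nc1C(Br)Br`: 372000 nM
- compound 2, `COC(=O)c1sc(-c2ccc(Cl)cc2)nc1C(C)C`: 49600 nM

Both were read in an ADME assay on BHK15 cells (Mesocricetus auratus) for inhibition, read by XTT assay, with a stated time of 36 h; on this read-out higher numbers stand for weaker inhibition of growth and lower numbers for stronger inhibition of growth. Compound 2 stands lowest of the two numbers; compound 1 gives a higher number, and the gap between them lies beyond the usual scatter. The two compounds differ at more than one place, so no single step can be drawn from them; only their two values are shown.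

Compound 3, `COC(=O)c1sc(-c2ccc(Cl)cc2)nc1C(Cl)Cl`, has not yet been measured in this assay. It differs from compound 2 as follows: dichloromethyl in place of isopropyl on an aromatic carbon

Going by the values given here, the only dihalomethyl compound so far, compound 1, gives the weaker value 372000 nM in this assay, though its ester also differs. On that basis the step for compound 3 is expected to be a 2.4-fold higher number from compound 2 to compound 3 (0.38 log units; beyond the scatter), in the direction of weaker inhibition. Compound 3 is estimated at 120000 nM in this assay, with a range from 40000 nM to 400000 nM.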

Compound 3, concentration for 50% growth inhibition: 34100 nM
Compound 3: the middle estimate sits 3.5-fold (0.55 log units) above what was measured; measured number outside the range, below it.
By their numbers in this assay, from the lowest: compounds 3 and 2 (each within the scatter of the next); then compound 1.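

On this position, next to the ring nitrogen, dichloromethyl in place of isopropyl gives a 1.5-fold lower number from compound 2 to compound 3 (0.16 log units; within the scatter) in this assay and so does not separate the two groups on this read-out. Isopropyl and dichloromethyl have the same count of heavy atoms, and on the methyl ester this exchange alone does not reproduce a number as high as that of compound 1 at 372000 nM in this series. Compound 1 differs from compound 3 in more than one place, so its number cannot be assigned to a single group. No available data bear on why the two groups read alike.

Open, going by these compounds, is whether an amine, a carboxylic acid or a longer chain at this position would move the number beyond the scatter. Also open, on these data alone, is how far the ester and the dihalomethyl group each contribute to the number of compound 1.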